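A few compounds are considered here, and "the series" means these few. Any claim that something is new, unique, unknown or untested is made for them only; others in the source may bear on it.

Measured so far in a physicochemical assay for lipophilicity; on this read-out higher numbers stand for higher lipophilicity and lower numbers for lower lipophilicity:
- compound 1 `COc1ccc(O)c(C2=N[C@@](C)(C(=O)O)CS2)c1`: -0.61
- compound 2 `C[C@]1(C(=O)O)CSC(c2ccc(O)cc2O)=N1`: -1.05

Only these two compounds have been measured. Compound 1 stands higher of the pair at -0.61, while compound 2 lies lower at -1.05, and this gap is beyond the usual scatter of repeated measurements.

The next compound to be measured is compound 3 `C[C@]1(C(=O)O)CSC(c2cc(O)ccc2O)=N1`. It differs from compound 1 in a single place: hydrogen in place of methyl on an oxygen on an aromatic ring. In words, hydrogen replaces methyl on an oxygen on an aromatic ring, so methoxy becomes hydroxy.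

Going by the values given here, no measured pair shows this exact change, so its size must be judged indirectly. Compound 2 also carries no methoxy, and compound 2 reads -1.05 in this assay. It is still a different compound from compound 3, so it offers only a rough guide. On that basis, a downward step beyond the scatter is expected, of about the size of the gap between the two measured compounds. The expected change is a number 0.49 log units lower from compound 1 to compound 3 (beyond the scatter). For compound 3 the estimated value is -1.1, with an expected range from -1.5 to -0.8.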

Compound 3, partition coefficient: -1.14
The estimate for compound 3 lay 0.04 log units above the measured number; the range from low to high includes it.
By their numbers in this assay, from the lowest: compounds 3 and 2 (each within the scatter of the next); then compound 1.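

In this assay, going by these compounds alone, this is the first direct reading of a single change at this position: hydrogen replacing methyl on an oxygen on an aromatic ring, so that methoxy becomes hydroxy, gives a number 0.53 log units lower from compound 1 to compound 3 (beyond the scatter). The earlier compounds shown here could not show this, since no two of them differed in one place only, whereas here the rest of the core of compound 1 stays the same and the step belongs to this one change. Nothing available explains the size or direction of the step, so it stands as an observation without a stated cause.

From the compounds shown here alone, whether a longer chain on the same oxygen, such as ethoxy, or an amine in place of the hydroxy would continue this trend or break it remains open. Going by these compounds, one pair also speaks for one place only, so whether the same change would give a similar step elsewhere on the aromatic ring, or on a different core, is still unknown.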